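Swapping a Methoxymethyl for a Hydroxymethyl Side Chain

The source may report more compounds than this note shows. Statements on the series, on what has been measured and on what is new or still open speak of the compounds shown alone.

In a functional assay on HL-60 cells (Homo sapiens) for cytotoxicity, read by WST assay, with a stated time of 48 h (a higher number here means a weaker inhibitor, a lower number a stronger inhibitor), compound 2 `COC[C@H](C)[C@@H](C)C(c1ccc(O)c(OC)c1)c1ccc(O)c(OC)c1` gives 68000 nM, the second highest of three numbers. Compound 1 `COC[C@H](C(C)C)C(c1ccc(O)c(OC)c1)c1ccc(O)c(OC)c1` gives 72000 nM, and compound 3 `COc1cc(C(c2ccc(O)c(OC)c2)[C@@H](C)[C@H](C)CF)ccc1O` gives 32000 nM. Compound 4 `COc1cc(C(c2ccc(O)c(OC)c2)[C@H](CO)C(C)C)ccc1O` differs from compound 2 in one place: 1-(hydroxymethyl)-2-methylpropyl in place of 2-(methoxymethyl)-1-methylpropyl on a saturated chain carbon bound to two aromatic carbons. Among the measured compounds shown here, no measured step turns a methoxymethyl into a hydroxymethyl. The nearest comparisons are a 1.1-fold lower number from compound 1 to compound 2 (0.02 log units; within the scatter), a 2.3-fold lower number from compound 1 to compound 3 (0.35 log units; beyond the scatter) and a 2.1-fold lower number from compound 2 to compound 3 (0.33 log units; beyond the scatter), modest at most; changes on this side chain have shifted this assay only a little. The step from this change is expected to be a 1.0-fold lower number from compound 2 to compound 4 (0.02 log units; within the scatter), within the scatter. The estimate for compound 4 is 65000 nM, expected to lie between 30000 nM and 140000 nM.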

Compound 4, half-maximal inhibitory concentration: > 100000 nM
Compound 4 gave a limit, no number (the forecaster's own chance of this, stated with the estimate: 5%); middle value at least 1.5-fold (0.18 log units) away from the limit.
By their numbers in this assay, from the lowest: compound 3; then compounds 2 and 1 (each within the scatter of the next). At a limit, above all of these: compound 4.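

In this assay compound 4 stands at a limit of the assay, not at a number: the limit of > 100000 nM in this assay, at which 1 of the 4 values shown sits. Hydrogen in place of methyl on the oxygen gives an at least 1.3-fold higher number from compound 1 to compound 4 (0.14 log units; that floor lies within the scatter), and the change from the 2-(methoxymethyl)-1-methylpropyl chain gives an at least 1.4-fold higher number from compound 2 to compound 4 (0.16 log units; that floor lies within the scatter), so neither floor alone establishes a real shift. The fluoromethyl comparison does clear the scatter, with an at least 3.1-fold higher number from compound 3 to compound 4 (0.49 log units; beyond the scatter), so this position can separate chains that end differently.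

From the compounds shown here alone, the true value of compound 4 stays open. So does the effect of an amine or a carboxylic acid at the end of this chain.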